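Compound 3: carbamoylmethyl in place of the five-membered ring

The source may report more compounds than this note shows. Statements on the series, on what has been measured and on what is new or still open speak of the compounds shown alone.

In a physicochemical assay for solubility, measured as kinetic solubility, at pH 2 (on this read-out lower numbers stand for lower solubility and higher numbers for higher solubility), compound 1 (`CC(C)C(Nc1nccs1)c1ccc(-c2ccc3cccc(F)c3c2)[nH]c1=O`) gives 32900 nM and compound 2 (`CC(C)C(c1noc(=O)[nH]1)c1ccc(-c2ccc3cccc(F)c3c2)[nH]c1=O`) gives 23200 nM. Going by the values given here, compound 2 therefore stands within the scatter of compound 1, its only measured neighbour. Compound 3 (`CC(C)C(CC(N)=O)c1ccc(-c2ccc3cccc(F)c3c2)[nH]c1=O`) has not yet been measured. Its difference from compound 2 is carbamoylmethyl entering on the saturated chain carbon: a group of 4 heavy atoms (2 carbon, 1 nitrogen, 1 oxygen; no ring) in place of a group of 6 heavy atoms (2 carbon, 2 nitrogen, 2 oxygen; one five-membered aromatic ring with 3 hetero atoms), on a saturated chain carbon bound to an aromatic carbon and a saturated chain carbon. Among the compounds with values here, the only step bearing on this change, a 1.4-fold lower number from compound 1 to compound 2 (0.15 log units; within the scatter), swaps one five-membered aromatic ring for another, so no step beyond the scatter is expected in this assay. This is a thin guide, as neither measured compound lacks such a ring at that place. The estimated step is a 1.0-fold higher number from compound 2 to compound 3 (0.01 log units; within the scatter). For compound 3 the estimated value is 24000 nM, with an expected range of 9000 nM to 60000 nM.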

Compound 3, solubility: 3120 nM
Estimate against measurement, compound 3: 7.7-fold (0.89 log units) above; the whole stated range lies above it.
By their numbers in this assay, from the lowest: compound 3; then compounds 2 and 1 (each within the scatter of the next).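

In this assay, going by these compounds alone, the saturated chain carbon bound to an aromatic carbon and a saturated chain carbon proves sensitive to the group placed on it: carbamoylmethyl, the only group here without a ring at that place, gives a 7.4-fold lower number from compound 2 to compound 3 (0.87 log units; beyond the scatter) and an 11-fold lower number from compound 1 to compound 3 (1.02 log units; beyond the scatter) while the two ring-bearing groups of compound 1 and compound 2 stay within the scatter of each other. Across these three compounds, then, the ring-bearing groups go with the higher numbers, with no compound against that pattern, though three compounds support little more than that. Nothing available accounts for this drop.

Open, going by these compounds, is whether the lower number follows from losing the ring or from carbamoylmethyl itself. A simple ethyl group, a carboxylic acid or an amine on a chain at the same carbon would help separate these two readings.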